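A Formyl-Methoxyphenyl Ether Replaces the Naphthyl Ether

This account rests on a few compounds, and the source may have more. Where it says the series, first, only, none or still open, it means among the compounds named here.

Compound 2 `COc1cc2c(cc1OC)CN(S(=O)(=O)c1ccc(-n3cc(COc4ccc5ccccc5c4)nn3)cc1)CC2` carries a naphthalen-2-yl ether on the shared core. In a functional assay on A549 cells (Homo sapiens) for cytotoxicity, read by MTT assay, with a stated time of 48 h (a lower number here means a stronger inhibitor, a higher number a weaker inhibitor), compound 2 gives > 50 ug/mL, which is a limit of the assay rather than a number. Compound 1 `COc1cc2c(cc1OC)CN(S(=O)(=O)c1ccc(-n3cc(COc4ccc([N+](=O)[O-])cc4)nn3)cc1)CC2` is its nearest neighbour; in this assay compound 1 likewise reaches only > 50 ug/mL, again a limit. The step that the two limits leave unreadable from compound 1 to compound 2 is therefore unreadable, since (the limit of > 50 ug/mL in this assay, at which 2 of the 2 values shown sit). Compound 3 `COc1cc2c(cc1OC)CN(S(=O)(=O)c1ccc(-n3cc(COc4ccc(C=O)cc4OC)nn3)cc1)CC2` is the next member and differs from compound 2 in one place: 4-formyl-2-methoxyphenyl in place of naphthalen-2-yl on an oxygen on a saturated carbon. Within the data shown here, no measured step speaks to this change, as the only known step, from compound 1 to compound 2, is hidden by the two limits. Among the measured compounds shown here, the expectation for compound 3 thus rests on what both measured compounds show, each sitting at the limit with no member falling below it. Compound 3 is expected to remain there in this assay, the estimated step that the limit leaves unreadable from compound 2 to compound 3 carrying no direction beyond the scatter. Compound 3 is estimated at 60 ug/mL, with a range from 25 ug/mL to 150 ug/mL, most likely reported once more as a limit only.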

Compound 3, half-maximal inhibitory concentration: > 50 ug/mL
Compound 3: no number, only a limit; the forecaster's own chance of this, stated with the estimate: 75%; the middle value lies beyond the limit too.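

Compound 3 gives only a limit, as compound 1 and compound 2 do, so no step among these three compounds can be read in this assay: the limit of > 50 ug/mL in this assay, at which 3 of the 3 values shown sit.

The compounds shown leave open whether any ether on the shared core would give a number in this assay, and how the 4-nitrophenyl, naphthalen-2-yl and 4-formyl-2-methoxyphenyl groups rank against one another.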